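The source may report more compounds than this note shows. Statements on the series, on what has been measured and on what is new or still open speak of the compounds shown alone.

Compound 3 `CC(C)CCn1ccc(-c2ccc(Oc3cccnc3)cc2)c(C#N)c1=O` gives 479 nM in a functional assay on CHO cells for positive allosteric modulation of metabotropic glutamate receptor 2 (Homo sapiens), read by scintillation counting and GTPgammaS binding, with a stated time of 30 min (on this read-out lower numbers stand for an effect already at smaller amounts and higher numbers for an effect only at larger amounts of compound), the lowest of the three numbers measured. Compound 1 `CC(C)CCn1ccc(-c2ccccc2)c(C#N)c1=O` gives 8510 nM, and compound 2 `COc1ccc(-c2ccn(CCC(C)C)c(=O)c2C#N)cc1F` gives 1170 nM. Within the data shown here, the only step measured between compounds that differ in a single place is an 18-fold lower number from compound 1 to compound 3 (1.25 log units; beyond the scatter). Compound 4 `Cc1ncccc1Oc1ccc(-c2ccn(CCC(C)C)c(=O)c2C#N)cc1` differs from compound 3 by methyl in place of hydrogen on an aromatic carbon. Among the measured compounds shown here, no measured step concerns a change on the six-membered aromatic ring with one nitrogen; the large step already seen introduced the whole (pyridin-3-yl)oxy group and offers no guide to a methyl on it. Compound 4 is therefore expected to show a 1.2-fold lower number from compound 3 to compound 4 (0.08 log units; within the scatter), nothing beyond the scatter. Compound 4 is estimated at 400 nM, between 150 nM and 1200 nM.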

Compound 4, half-maximal effective concentration: 275 nM
Estimate against measurement, compound 4: 1.5-fold (0.16 log units) above; the range from low to high includes it.
By their numbers in this assay, from the lowest: compounds 4 and 3 (each within the scatter of the next); then compound 2; then compound 1.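

On the six-membered aromatic ring with 1 nitrogen, methyl next to the ring nitrogen and ortho to a large group is accepted in this assay, with a 1.7-fold lower number from compound 3 to compound 4 (0.24 log units; within the scatter) as the whole effect of this change. The (2-methylpyridin-3-yl)oxy group in place of hydrogen gives a 31-fold lower number from compound 1 to compound 4 (1.49 log units; beyond the scatter) on the core of compound 1, so the large gain in this read-out persists with the added methyl. Nothing measured here explains either step. As far as these compounds go, whether an ethyl, a methoxy or an amine would be accepted at this carbon remains open. So does the effect of a methyl on the other carbons of this ring.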